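Trading a dichlorinated ring for a fluorinated one

A few compounds are considered here, and "the series" means these few. Any claim that something is new, unique, unknown or untested is made for them only; others in the source may bear on it.

Measured so far in an assay on isolated protein for inhibition of Dihydrofolate reductase (Homo sapiens), read by spectrophotometry, using NADPH, with stated times of 5 s and 6 min, tested at 5 uM; a higher number here means a stronger effect of the compound at the concentration tested, a lower number a weaker effect:
compound 1, `NC1=NC2(CCSCC2)N(OCCCOc2cccc(Cl)c2)C(N)=N1`: 88.3%
compound 2, `NC1=NC2(CCOCC2)N(OCCCOc2cccc(Cl)c2)C(N)=N1`: 83.2%
compound 3, `NC1=NC2(CCOCC2)N(OCCCOc2ccc(Cl)c(Cl)c2)C(N)=N1`: > 90%

Compound 3 carries 3,4-dichlorophenyl on an oxygen on a saturated carbon. For compound 3 the value in this assay is a limit of the assay, not a number, so the reading the limit of > 90% in this assay, at which 1 of the 3 values shown sits, marks only a floor, not where the compound truly stands.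

Compound 4 is `NC1=NC2(CCOCC2)N(OCCCOc2ccc(F)cc2)C(N)=N1`, and it differs from compound 3 by 4-fluorophenyl in place of 3,4-dichlorophenyl on an oxygen on a saturated carbon.

For the measured compounds named here, one measured step touches this aromatic ring: a number at least 6.8 percentage points higher from compound 2 to compound 3 (that floor lies within the scatter). The change from compound 3 to compound 4 runs the other way, from 3,4-dichlorophenyl to 4-fluorophenyl, so a drop is expected rather than a rise, and it may well reach beyond the scatter. The step from compound 3 to compound 4 is therefore expected to be about a number at least 20 percentage points lower from compound 3 to compound 4 (beyond the scatter). For compound 4 the estimated inhibition in this assay is 70%, expected to fall between 50% and 88%.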

Compound 4, a percentage reported as inhibition, at one concentration (the size of the read-out at that concentration, not a potency): > 90%
Compound 4 was reported as a limit; the forecaster's own chance of this, stated with the estimate: 10%; at least 20 percentage points between middle value and limit.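

In this assay compound 4 gives > 90%, which is a limit of the assay, so 4-fluorophenyl on this oxygen loses nothing this test can detect compared with 3,4-dichlorophenyl. Placing 4-fluorophenyl where 3-chlorophenyl stood gives a number at least 6.8 percentage points higher from compound 2 to compound 4 (that floor lies within the scatter), so no gain from this change can be claimed. The step from compound 3 to compound 4 cannot be read, because both compounds sit at the same limit: the limit of > 90% in this assay, at which 2 of the 4 values shown sit.

Which of these two rings serves the enzyme better therefore stays open, and only a reading that is not held at this limit could settle it. Also open, from the compounds shown here alone, is whether an unsubstituted phenyl ring, a 4-methoxyphenyl group or a longer chain in front of the ring would hold the read-out at this level.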